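Carboxyphenoxy Exchanged for Methoxyphenyl on a Shared Core

This account rests on a few compounds, and the source may have more. Where it says the series, first, only, none or still open, it means among the compounds named here.

Compound 1, `Cc1ccccc1-n1nc(C)c2c1NC(=O)[C@H](C)S[C@@H]2c1ccc(Oc2ccccc2C(=O)O)cc1`: "not active" (no number reported)
Compound 2, `Cc1nn(-c2ccccc2C(F)(F)F)c2c1C(c1ccc(Oc3ccccc3)cc1)SC(C)C(=O)N2`: 2000 nM
Compound 3, `CCc1ccccc1-n1nc(C)c2c1NC(=O)[C@H](C)S[C@@H]2c1ccc(Oc2ccccc2)cc1`: 1100 nM

In an assay on isolated protein for agonist activity at Bile acid receptor (Homo sapiens), read by AlphaScreen, with a stated time of 30 min (on this read-out higher numbers stand for an effect only at larger amounts of compound and lower numbers for an effect already at smaller amounts), compound 1 gives "not active" (no number reported), so no number stands against it and its place among the others cannot be fixed. Compound 2 gives 2000 nM and compound 3 gives 1100 nM; these two values lie within the scatter of each other. Compound 4, `COc1ccccc1-c1ccc([C@H]2S[C@@H](C)C(=O)Nc3c2c(C)nn3-c2ccccc2C)cc1`, has not yet been measured. It differs from compound 1 in one place: 2-methoxyphenyl in place of 2-carboxyphenoxy on an aromatic carbon. For the measured compounds named here, no measured pair shows this change, so neither its size nor its direction is known; compound 1 offers no number, and only the values of compounds 2 and 3 give a scale. Compound 4 is expected to give about 3000 nM in this assay, most likely between 700 nM and 15000 nM.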

Compound 4, half-maximal effective concentration: 1100 nM
Beside the measured number, compound 4's estimate is 2.7-fold (0.44 log units) above it; low and high end bracket the measured number.
By their numbers in this assay, from the lowest: compounds 3, 4 and 2 (each within the scatter of the next).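

In this assay, for the compounds shown here, compound 1 has no number, so no step from it to compound 4 can be read. The compounds shown leave open what exchanging 2-carboxyphenoxy for 2-methoxyphenyl does to the value. No measured evidence bears on this result.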